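The source may report more compounds than this note shows. Statements on the series, on what has been measured and on what is new or still open speak of the compounds shown alone.

Three compounds built on one shared core have been examined in an assay on isolated protein for inhibition of Polyunsaturated fatty acid 5-lipoxygenase (Homo sapiens); a higher number here means a weaker inhibitor, a lower number a stronger inhibitor. Compound 1 `CCc1cccc(N2CCCC(=O)N2)c1` gives 3000 nM in this assay. Compound 3 `O=C1CCCN(c2cccc(Cl)c2)N1` gives 2500 nM in this assay. The change between them is chloro in place of ethyl on an aromatic carbon and it made a 1.2-fold lower number from compound 1 to compound 3 (0.08 log units; within the scatter). Compound 2 `CCc1ccc(N2CCCC(=O)N2)cc1` gives 125000 nM in this assay. Compound 2 and compound 1 are made of the same atoms joined differently; the difference between the two cores is not broken down here. Compound 2 stands highest of the three numbers, with compound 1 nearest and compound 3 furthest, both gaps beyond the scatter.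

Compound 4 `O=C1CCCN(c2ccc(Cl)cc2)N1` has not yet been measured in this assay. It differs from compound 2 by chloro in place of ethyl on an aromatic carbon. This is the same kind of change as that from compound 1 to compound 3, but not the same: in the measured pair the entering chloro stands meta to a group of 7 heavy atoms, whereas in compound 4 it stands para to a group of 7 heavy atoms. Resting on the measured step of a 1.2-fold lower number from compound 1 to compound 3 (0.08 log units; within the scatter), the same kind of change is expected to make a similarly small step, estimated as a 1.3-fold lower number from compound 2 to compound 4 (0.10 log units; within the scatter). Going by the values given here, since only one measured pair shows this change, and at a different place, the estimate is held with a wide range. Compound 4 is expected to give about 100000 nM in this assay, estimated to lie between 30000 nM and 300000 nM.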

Compound 4, half-maximal inhibitory concentration: 79000 nM
The estimate for compound 4 lay 1.3-fold (0.10 log units) above the measured number; low and high end bracket the measured number.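

In this assay, chloro in place of ethyl on an aromatic carbon made a 1.6-fold lower number from compound 2 to compound 4 (0.20 log units; within the scatter), so on this core, as on the earlier one, the swap left the number within the scatter. Set side by side, the two steps do not differ, and in this series the change carried from one core to the other without a measurable change in its size: the same change on two cores in this assay, a 1.2-fold lower number (0.08 log units; within the scatter) from compound 1 to compound 3 and a 1.6-fold lower number (0.20 log units; within the scatter) from compound 2 to compound 4, 1.3-fold (0.12 log units) apart, within the scatter of two such steps. Going by these compounds alone, this does not show that chloro and ethyl can be exchanged freely across the series, since the agreement rests on only two pairs, each step is too small to count as a gain or a loss, and neither pair says anything about why the two groups give such similar numbers.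

The compounds shown leave open how a group other than ethyl or chloro, such as an amine, a carboxylic acid or a longer chain, would behave on the aromatic ring, and whether such a group would give matching steps on the two cores. They also leave open whether the agreement would hold for a change made elsewhere on the shared core, for instance at the carbonyl or the amide hydrogen.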